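A few compounds are considered here, and "the series" means these few. Any claim that something is new, unique, unknown or untested is made for them only; others in the source may bear on it.

Compound 1 `O=C(c1ccc(Cl)nc1)N1CCC(NS(=O)(=O)c2cc(S(=O)(=O)c3ccccc3)ccc2C(F)(F)F)CC1` is one of three compounds that share a core and differ only in the group carried on the nitrogen of the ring amine. In an assay on U2OS cells for inhibition of secreted frizzled-related protein 1 (Homo sapiens), read by a luciferase reporter, with a stated time of 18 h (on this read-out higher numbers stand for an effect only at larger amounts of compound and lower numbers for an effect already at smaller amounts), compound 1 gives 140 nM, the lowest of the three numbers. Compound 2 `N#Cc1cccc(S(=O)(=O)N2CCC(NS(=O)(=O)c3cc(S(=O)(=O)c4ccccc4)ccc3C(F)(F)F)CC2)c1` gives 170 nM in this assay, and the step of a 1.2-fold higher number from compound 1 to compound 2 (0.08 log units; within the scatter) lies within the scatter. Compound 3 `O=C(O)CCCC(=O)N1CCC(NS(=O)(=O)c2cc(S(=O)(=O)c3ccccc3)ccc2C(F)(F)F)CC1` gives 570 nM, and the steps of a 4.1-fold higher number from compound 1 to compound 3 (0.61 log units; beyond the scatter) and a 3.4-fold higher number from compound 2 to compound 3 (0.53 log units; beyond the scatter) are both beyond the scatter.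

Compound 4 `O=C([C@H]1CCNC1)N1CCC(NS(=O)(=O)c2cc(S(=O)(=O)c3ccccc3)ccc2C(F)(F)F)CC1` has not been measured in this assay. Its difference from compound 1 is pyrrolidin-3-yl in place of 6-chloropyridin-3-yl on a carbonyl carbon. The step that bears most directly on it is a 4.1-fold higher number from compound 1 to compound 3 (0.61 log units; beyond the scatter), where an aromatic ring on the carbonyl carbon gave way to an open chain carrying a donor, and the number rose modestly; a 3.4-fold higher number from compound 2 to compound 3 (0.53 log units; beyond the scatter) points the same way. Compound 4 also exchanges the aromatic ring for a non-aromatic group with a hydrogen-bond donor, so a modest rise in the number is expected for compound 4, estimated as a 2.9-fold higher number from compound 1 to compound 4 (0.46 log units; beyond the scatter). On that basis compound 4 is expected to give about 400 nM in this assay, with a likely range from 150 nM to 1100 nM.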

Compound 4, half-maximal effective concentration: 700 nM
The estimate for compound 4 lay 1.8-fold (0.24 log units) below the measured number; low and high end bracket the measured number.
By their numbers in this assay, from the lowest: compounds 1 and 2 (each within the scatter of the next); then compounds 3 and 4 (each within the scatter of the next).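

In this assay, the change on the carbonyl carbon from 6-chloropyridin-3-yl to pyrrolidin-3-yl, a non-aromatic ring with a hydrogen-bond donor and a defined stereocentre, gives a 5.0-fold higher number from compound 1 to compound 4 (0.70 log units; beyond the scatter), and the change at the ring amine nitrogen from (3-cyanophenyl)sulfonyl to (pyrrolidin-3-yl)carbonyl gives a 4.1-fold higher number from compound 2 to compound 4 (0.61 log units; beyond the scatter). Earlier, only the open chain of compound 3 had stood against the aromatic groups, but a non-aromatic ring now reaches the same level, with a 1.2-fold higher number from compound 3 to compound 4 (0.09 log units; within the scatter), so among these four compounds the two with aromatic rings in this group hold the lower numbers, none goes against that, and ring and open chain are not told apart. Nothing in the data given accounts for this difference.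

The compounds shown do not separate the loss of the aromatic ring from the loss of the chlorine or the gain of the amine, and a cyclopentyl group or an unsubstituted pyridin-3-yl group on the carbonyl carbon would bear on that. The mirror-image pyrrolidin-3-yl group would show whether the stereocentre matters at this position.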